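The source may report more compounds than this note shows. Statements on the series, on what has been measured and on what is new or still open speak of the compounds shown alone.

Of the compounds shown here, three sharing one core have been measured in an assay on membranes from HEK293 cells for displacement of a labelled ligand from adenosine receptor A2b (Homo sapiens), read by scintillation counting, with a stated time of 30 min, tested at 1 uM; a higher number here means more inhibition at the concentration tested (going by the name of the read-out), a lower number less inhibition. Compound 1 `CC1=C(C(=O)CC(C)C)C(c2cccs2)NC(=O)N1` gives 43%. Compound 2 `CCN(CC)C(=O)C1=C(C)NC(=O)NC1c1cccs1` gives 22%, and compound 3 `CCSC(=O)C1=C(C)NC(=O)NC1c1cccs1` gives 1%. Compound 3 therefore stands lowest of the three, with compound 2 nearest and compound 1 furthest. The two other compounds differ from compound 3 only in the group on the carbonyl carbon, and both steps run downward toward it: a number 42 percentage points lower from compound 1 to compound 3 (beyond the scatter) and a number 21 percentage points lower from compound 2 to compound 3 (beyond the scatter). Compound 4 `CC1=C(C(=O)OC2CCCC2)C(c2cccs2)NC(=O)N1` has not yet been measured. It differs from compound 3 in one place: cyclopentyloxy in place of ethylsulfanyl on a carbonyl carbon. Going by the values given here, no measured step brings in cyclopentyloxy, so the known steps bear on this change only indirectly. They show that ethylsulfanyl, the group leaving, gave the lowest number of the three, while the two other groups placed on this carbonyl carbon gave more. On that basis a rise beyond the scatter is expected, a number 24 percentage points higher from compound 3 to compound 4 (beyond the scatter). Compound 4 is therefore estimated at 25%, within a range from 5% to 50%.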

Compound 4, a percentage reported as inhibition, at one concentration (the size of the read-out at that concentration, not a potency): 1%
Estimate against measurement, compound 4: 24 percentage points above; measured number outside the range, below it.
By their numbers in this assay, from the lowest: compounds 3 and 4 (each within the scatter of the next); then compound 2; then compound 1.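

In this assay, replacing ethylsulfanyl with cyclopentyloxy on this carbonyl carbon gives no change at the digits printed from compound 3 to compound 4 (within the scatter), so a low number here is not confined to the sulfur-linked group and persists with an oxygen-linked group carrying a five-membered carbon ring. The gaps to the other two groups are also beyond the scatter, with a number 21 percentage points lower from compound 2 to compound 4 (beyond the scatter) and a number 42 percentage points lower from compound 1 to compound 4 (beyond the scatter), which places the oxygen-linked group with ethylsulfanyl and apart from both diethylamino and isobutyl. Nothing available explains why these groups read as they do.

Ethoxy, the direct oxygen counterpart of ethylsulfanyl, would separate the effect of the linking atom from that of the ring, and it is absent from the compounds shown. On these data alone, a smaller amine such as dimethylamino, or a carboxylic acid at this place, also remains open.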